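A few compounds are considered here, and "the series" means these few. Any claim that something is new, unique, unknown or untested is made for them only; others in the source may bear on it.

Measured so far:
compound 1, `COc1cc(-c2nn(-c3cccc(NC(=O)Nc4cc(C(F)(F)F)cc(C(F)(F)F)c4)c3)cc2-c2ccncc2)ccc1Cl`: 310 nM
compound 2, `COc1cc(-c2nn(-c3cccc(NC(=O)Nc4cccc(C(F)(F)F)c4)c3)cc2-c2ccncc2)ccc1Cl`: 340 nM

Both compounds were tested in a functional assay on RPMI-8226 cells (Homo sapiens) for inhibition, read by sulforhodamine B assay, with a stated time of 48 h; a lower number here means a stronger inhibitor, a higher number a weaker inhibitor. Compound 2 gives the highest of the two numbers, but its nearest neighbour is compound 1, and the change from compound 1 to compound 2, a hydrogen in place of one trifluoromethyl on the outer ring of the urea, amounts to a 1.1-fold higher number from compound 1 to compound 2 (0.04 log units; within the scatter); the two values cannot be told apart.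

Compound 3, `COc1cc(-c2nn(-c3cccc(NC(=O)c4ccccc4)c3)cc2-c2ccncc2)ccc1Cl`, has not yet been measured. It differs from compound 2 in one place: phenyl in place of (3-(trifluoromethyl)phenyl)amino on a carbonyl carbon. The urea thus becomes a plain benzamide, losing both the remaining trifluoromethyl and the amide-type nitrogen that carried a hydrogen-bond donor.

Among the measured compounds shown here, only one measured step bears on this change, a 1.1-fold higher number from compound 1 to compound 2 (0.04 log units; within the scatter), and it covers just the trifluoromethyl part, not the loss of the nitrogen. For the trifluoromethyl alone no change beyond the scatter is expected; for the lost donor there is no measured guide, so a modest rise in the number is expected, about a 2.4-fold higher number from compound 2 to compound 3 (0.37 log units; beyond the scatter). For compound 3 the expected value in this assay is 800 nM, within a range from 250 nM to 3000 nM.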

Compound 3, half-maximal inhibitory concentration: 850 nM
Compound 3: the middle estimate sits 1.1-fold (0.03 log units) below what was measured; low and high end bracket the measured number.
By their numbers in this assay, from the lowest: compounds 1 and 2 (each within the scatter of the next); then compound 3.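

Among the compounds shown here, replacing (3-(trifluoromethyl)phenyl)amino with phenyl on the carbonyl carbon is the first change here to move the number in this assay beyond the scatter, with a 2.5-fold higher number from compound 2 to compound 3 (0.40 log units; beyond the scatter). The earlier change on the outer ring stayed within the scatter, with a 1.1-fold higher number from compound 1 to compound 2 (0.04 log units; within the scatter), so this site shows a measurable, though modest, response only when the amide-type nitrogen and the remaining trifluoromethyl leave together. No supporting measurement is available to explain the rise.

For the compounds shown here, the single step cannot show how much of the rise belongs to the nitrogen and how much to the trifluoromethyl; phenylamino on the carbonyl carbon would keep the nitrogen without the trifluoromethyl, while 3-(trifluoromethyl)phenyl would keep the trifluoromethyl without the nitrogen. On these data alone, it also remains open how this site would respond to a group without an aromatic ring, such as a cyclohexyl or a longer alkyl chain on the same carbonyl carbon.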